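Replacing the bromothiophene arm: outlook for compound 4

The compounds below may be only part of what the source reports. "The series", "measured", "known", "first", "only" and "open" are said of these compounds alone.

Compound 1 `O=C1N=C(N2CCC[C@H]2C(=O)Nc2ccc3ncnc(Nc4cccc(Cl)c4)c3c2)S/C1=C/c1ccc(Br)s1` is the starting point. In a functional assay on HepG2 cells (Homo sapiens) for antiproliferative activity, read by MTT assay (a higher number here means a weaker inhibitor, a lower number a stronger inhibitor), compound 1 reaches only the limit of the assay, > 50000 nM, so its position on the scale is not a number but a limit (the limit of > 50000 nM in this assay, at which 1 of the 3 values shown sits). Compound 2 `O=C1N=C(N2CCC[C@H]2C(=O)Nc2ccc3ncnc(Nc4cccc(Cl)c4)c3c2)S/C1=C/c1cccs1` gives 4120 nM in this assay, and compound 3 `O=C1N=C(N2CCC[C@H]2C(=O)Nc2ccc3ncnc(Nc4cccc(Cl)c4)c3c2)S/C1=C/c1cccc(Br)n1` gives 2700 nM. Both differ from compound 1 at the same arm: an at least 12-fold lower number from compound 1 to compound 2 (1.08 log units; beyond the scatter) and an at least 18-fold lower number from compound 1 to compound 3 (1.26 log units; beyond the scatter), each a large step to a lower number; between the two, a 1.5-fold lower number from compound 2 to compound 3 (0.18 log units; within the scatter).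

Compound 4 `O=C1N=C(N2CCC[C@H]2C(=O)Nc2ccc3ncnc(Nc4cccc(Cl)c4)c3c2)S/C1=C/c1ccccc1[N+](=O)[O-]` changes the same arm: 2-nitrophenyl in place of 5-bromothiophen-2-yl on a double-bonded chain carbon bound to a double-bonded ring carbon. Since every measured exchange of this arm gave lower numbers, compound 4 is expected to show an at least 12-fold lower number from compound 1 to compound 4 (1.09 log units; beyond the scatter), moving from the limit into measurable range. The estimate for compound 4 is 4000 nM, within 1000 nM to 20000 nM.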

Compound 4, half-maximal inhibitory concentration: 32500 nM
Estimate against measurement, compound 4: 8.1-fold (0.91 log units) below; the whole stated range lies below it.
By their numbers in this assay, from the lowest: compounds 3 and 2 (each within the scatter of the next); then compound 4. At a limit, above all of these: compound 1.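

In this assay, exchanging the 5-bromothiophen-2-yl arm does not always bring a large move to a lower number, as compound 4 shows: an at least 1.5-fold lower number from compound 1 to compound 4 (0.18 log units; that floor lies within the scatter). Compound 1 stands at a limit and not at a number: the limit of > 50000 nM in this assay, at which 1 of the 4 values shown sits. The entering group matters at this place, with a 12-fold higher number from compound 3 to compound 4 (1.08 log units; beyond the scatter) and a 7.9-fold higher number from compound 2 to compound 4 (0.90 log units; beyond the scatter).

Open, going by these compounds, is whether the higher number of compound 4 follows the nitro group or the six-membered ring of carbon only. A plain phenyl arm, or a phenyl arm carrying an amine, would separate the two.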